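Removing the aromatic hydroxy from compound 1

The source may report more compounds than this note shows. Statements on the series, on what has been measured and on what is new or still open speak of the compounds shown alone.

Measured in a functional assay on CCRF-CEM/VCR-1000 cells (Homo sapiens) for inhibition; a lower number here means a stronger inhibitor, a higher number a weaker inhibitor:
compound 1 `CC(C)N(CC(O)COc1ccc(O)cc1C(=O)CCc1ccccc1)C(C)C`: 1040 nM
compound 2 `COC(CCc1ccccc1)c1ccccc1OCC(O)CN(C(C)C)C(C)C`: 660 nM
compound 3 `CCCNCC(O)COc1ccc(OCc2ccccc2)cc1C(=O)CCc1ccccc1`: 110 nM

Compound 1 has the highest number of the three. Compound 2 comes nearest, and its number lies within the scatter of that of compound 1, so nothing separates the two. Compound 3 shows the lowest number, and its gap to compound 1 is beyond the scatter. Among the measured compounds shown here, no pair of measured compounds differs in only one place, so no measured step is available to guide the next change.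

Compound 4 `CC(C)N(CC(O)COc1ccccc1C(=O)CCc1ccccc1)C(C)C` is compound 1 with the change (hydrogen in place of hydroxy on an aromatic carbon). The two compounds share everything else. For the measured compounds named here, with no single-point step in hand, the size of this step in this assay cannot be read from the data; the expectation is a step of no more than the scatter, leaning toward a lower number, as compound 2, which also lacks a hydroxy on its core, gives 660 nM. Compound 4 is therefore estimated at 700 nM, within 250 nM to 2000 nM, which means an expected step of a 1.5-fold lower number from compound 1 to compound 4 (0.17 log units; within the scatter).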

Compound 4, half-maximal inhibitory concentration: 310 nM
Compound 4: the middle estimate sits 2.3-fold (0.35 log units) above what was measured, within the range that was stated.
By their numbers in this assay, from the lowest: compound 3; then compound 4; then compounds 2 and 1 (each within the scatter of the next).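

In this assay, hydrogen in place of hydroxy on this aromatic carbon gives a 3.4-fold lower number from compound 1 to compound 4 (0.53 log units; beyond the scatter), a modest step and the first in the series that can be assigned to a single position. The hydroxy at this place, meta to one large group and para to another, is therefore not required for inhibition on the core of compound 1, and inhibition is stronger without it. No measurement at hand explains the size or direction of this step.

Still open, from the compounds shown here alone, is whether a different replacement at this carbon, such as fluorine or an amino group, would go the same way as hydrogen. Also open, going by these compounds, is whether the step carries over when a piperidine replaces the diisopropylamino group of compound 1.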